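The compounds below may be only part of what the source reports. "The series", "measured", "known", "first", "only" and "open" are said of these compounds alone.

Measured so far in a functional assay on cells for agonist activity at Free fatty acid receptor 1 (Homo sapiens), read by FLIPR and calcium flux, with a stated time of 100 s; a higher number here means that more compound is needed for the effect, a lower number that less compound is needed:
Compound 1, `O=C(O)CC1CCN(c2ccc(OCc3ccc(Cl)cc3Cl)cc2)C1`, gives only a limit of the assay, > 33000 nM.
Compound 2, `Cc1ccccc1Cc1ccc(N2CCC[C@H]2CC(=O)O)cc1`, gives 150 nM.
Compound 3, `Cc1ccccc1Cc1ccc(N2CC[C@H](C)[C@H]2CC(=O)O)cc1`, gives 120 nM.

Compound 2 therefore holds the highest of the two numbers given; its nearest neighbour is compound 3, separated by a 1.3-fold lower number from compound 2 to compound 3 (0.10 log units; within the scatter). Compound 4, `Cc1ccccc1Cc1ccc(N2C[C@@H](C(F)(F)F)C[C@H]2CC(=O)O)cc1`, differs from compound 2 by trifluoromethyl in place of hydrogen on a saturated ring carbon. Within the data shown here, the one measured step that bears on this change is the one from compound 2 to compound 3, a methyl entering on a saturated ring carbon of the same ring, and it stayed within the scatter. On that basis no step beyond the scatter is expected in this assay for a trifluoromethyl entering on a saturated ring carbon. Compound 4 is thus estimated to give 150 nM, with a range from 50 nM to 450 nM. The expected step of no change at the digits printed from compound 2 to compound 4 (within the scatter) is accordingly none beyond the scatter.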

Compound 4, half-maximal effective concentration: 67 nM
Estimate against measurement, compound 4: 2.2-fold (0.35 log units) above, and the stated range covers the measured number.
By their numbers in this assay, from the lowest: compounds 4, 3 and 2 (each within the scatter of the next, the first and the last beyond it). At a limit, above all of these: compound 1.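

In this assay, trifluoromethyl in place of hydrogen on this saturated ring carbon, two ring bonds from the ring nitrogen, gives a 2.2-fold lower number from compound 2 to compound 4 (0.35 log units; beyond the scatter), a modest step but the first on this ring to lie beyond the scatter. The earlier methyl entry, a 1.3-fold lower number from compound 2 to compound 3 (0.10 log units; within the scatter), had shown no such step, and this ring carbon now proves to accept trifluoromethyl with no rise in the number. Nothing at hand accounts for the step. The compounds shown leave open whether a methyl, a single fluorine or a hydroxyl group on this same ring carbon would give a similar step, and whether the opposite configuration there would.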